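A few compounds are considered here, and "the series" means these few. Any claim that something is new, unique, unknown or untested is made for them only; others in the source may bear on it.

Measured compounds:
Compound 1, `Nc1cc(N)c2nc(-c3ccccc3)c(Oc3ccc(F)cc3)nc2c1` — 8320 nM
Compound 2, `COc1ccc(CNc2nc3cc(N)cc(N)c3nc2-c2ccccc2)cc1OC` — 8320 nM
Compound 3, `COc1ccc(CNc2nc3cc(N)cc(N)c3nc2-c2ccccc2)cc1` — 10200 nM

In a functional assay on PC-3 cells (Homo sapiens) for inhibition, read by sulforhodamine B assay, with a stated time of 48 h (on this read-out lower numbers stand for stronger inhibition of growth and higher numbers for weaker inhibition of growth), compound 1 gives 8320 nM, level with compound 2 at the digits shown and, together with it, the lowest of the three numbers. Compound 3 lies furthest away, yet only by a difference that stays within the scatter. Within the data shown here, the one measured step, a 1.2-fold higher number from compound 2 to compound 3 (0.09 log units; within the scatter), is within the scatter as well and concerns hydrogen in place of methoxy on an aromatic carbon; it does not touch the group that changes here.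

Compound 4, `COc1ccc(Sc2nc3cc(N)cc(N)c3nc2-c2ccccc2)cc1`, differs from compound 1 in one place: (4-methoxyphenyl)sulfanyl in place of 4-fluorophenoxy on an aromatic carbon. The change sits on the shared core, on an aromatic carbon of a six-membered aromatic ring with two nitrogens, next to the ring nitrogen and ortho to a phenyl group. Among the measured compounds shown here, no measured step covers this exchange, so the only guide is that all three measured numbers sit close together. Compound 4 is therefore expected to show no step beyond the scatter, a 1.0-fold higher number from compound 1 to compound 4 (0.01 log units; within the scatter), and its estimated value is 8500 nM with a range from 3000 nM to 25000 nM.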

Compound 4, concentration for 50% growth inhibition: 1740 nM
Beside the measured number, compound 4's estimate is 4.9-fold (0.69 log units) above it; measured number outside the range, below it.
By their numbers in this assay, from the lowest: compound 4; then compounds 1, 2 and 3 (each within the scatter of the next).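

In this assay the exchange of 4-fluorophenoxy for (4-methoxyphenyl)sulfanyl gives a 4.8-fold lower number from compound 1 to compound 4 (0.68 log units; beyond the scatter) and is the first step among these compounds that lies beyond the scatter. Among these compounds, the aromatic carbon next to the ring nitrogen and ortho to a phenyl group is thus a place where the group can shift the number, which the earlier compounds, whose numbers all lay within the scatter of one another, did not show. The exchange alters both the linking atom and the ring substituent at once, so the step cannot be assigned to either part, and no measurement at hand bears on its cause.

The compounds shown leave open how a 4-methoxyphenoxy or a 4-fluorophenylsulfanyl group would read at this carbon. They also leave open what a carboxylic acid or a longer alkyl chain would do there.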